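The compounds below may be only part of what the source reports. "The series", "measured", "known", "first", "only" and "open" are said of these compounds alone.

Two compounds of the series have been run in a functional assay on cells for agonist activity at G-protein coupled receptor 52 (Homo sapiens), read by AlphaScreen and cAMP accumulation, with a stated time of 30 min (a lower number here means that less compound is needed, a higher number that more compound is needed for the effect), so far. Compound 1 `CCc1cc(-c2sc(Cc3cccc(C(F)(F)F)c3)nc2C)ccc1C(N)=O` gives 83 nM. Compound 2 `COc1cc(-c2sc(Cc3cccc(C(F)(F)F)c3)nc2C)ccc1C(N)=O` gives 170 nM. Among the measured compounds shown here, the only step between them, a 2.0-fold higher number from compound 1 to compound 2 (0.31 log units; beyond the scatter), leaves compound 2 with the higher of the two numbers and compound 1 as its nearest neighbour.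

Compound 3 `Cc1nc(Cc2cccc(C(F)(F)F)c2)sc1-c1ccc(C(N)=O)c(C(F)(F)F)c1` differs from compound 2 in one place: trifluoromethyl in place of methoxy on an aromatic carbon. For the measured compounds named here, no measured step bears directly on this exchange; the single step seen so far, from ethyl to methoxy, was modest in size, and neither of the two measured groups is the one that enters here. Going by the values given here, with no precedent for trifluoromethyl on this ring, the working expectation for compound 3 is a step about the size of scatter, a 1.1-fold lower number from compound 2 to compound 3 (0.05 log units; within the scatter), in either direction. Compound 3 is therefore estimated at 150 nM, with a range from 50 nM to 450 nM.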

Compound 3, half-maximal effective concentration: 110 nM
Beside the measured number, compound 3's estimate is 1.4-fold (0.13 log units) above it; the range from low to high includes it.
By their numbers in this assay, from the lowest: compounds 1, 3 and 2 (each within the scatter of the next, the first and the last beyond it).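

At this aromatic carbon, ortho to a carbamoyl group, trifluoromethyl with 4 heavy atoms and 0 hydrogen-bond acceptors keeps the response in this assay within the scatter of both neighbours (a 1.5-fold lower number from compound 2 to compound 3 (0.19 log units; within the scatter)) (a 1.3-fold higher number from compound 1 to compound 3 (0.12 log units; within the scatter)). Compound 3 therefore falls within the scatter of both compound 1 and compound 2, although those two stand apart (a 2.0-fold higher number from compound 1 to compound 2 (0.31 log units; beyond the scatter)), so the three groups tested here give numbers in one narrow band and no clear order can be read from compound 3. Nothing at hand explains this result.

From the compounds shown here alone, whether an amine, a hydroxyl or a longer chain on this carbon stays in the same band remains open, as does the effect of plain hydrogen there. The compounds shown vary only this one place, so how the rest of the shared core contributes is also open.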